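Fluoro for methyl on the sulfonyl aryl ring

This account rests on a few compounds, and the source may have more. Where it says the series, first, only, none or still open, it means among the compounds named here.

In an ADME assay on Vero cells (Chlorocebus sabaeus) for cytotoxicity, read by polymerase chain reaction, with a stated time of 18 h (on this read-out higher numbers stand for lower toxicity in this test and lower numbers for higher toxicity in this test), compound 2 `Cc1ccc(S(=O)(=O)Oc2ccc3c(CSc4nc5ccccc5c(=O)[nH]4)cc(=O)oc3c2)cc1` gives 117000 nM, the lowest of the two numbers in hand. Compound 1 `O=c1cc(CSc2nc3ccccc3c(=O)[nH]2)c2ccc(OS(=O)(=O)c3ccccc3)cc2o1` gives 178000 nM, and the step of a 1.5-fold lower number from compound 1 to compound 2 (0.18 log units; within the scatter) lies within the scatter. Compound 3 `O=c1cc(CSc2nc3ccccc3c(=O)[nH]2)c2ccc(OS(=O)(=O)c3ccc(F)cc3)cc2o1` differs from compound 2 by fluoro in place of methyl on an aromatic carbon, on the aromatic carbon para to a large group. Within the data shown here, the only measured step concerns that same carbon and stayed within the scatter, so no step beyond the scatter is expected in this assay. Compound 3 is therefore estimated at 140000 nM, between 60000 nM and 320000 nM. The expected step is a 1.2-fold higher number from compound 2 to compound 3 (0.08 log units; within the scatter).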

Compound 3, half-maximal cytotoxic concentration: 30000 nM
Estimate against measurement, compound 3: 4.7-fold (0.67 log units) above; the whole stated range lies above it.
By their numbers in this assay, from the lowest: compound 3; then compounds 2 and 1 (each within the scatter of the next).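

At this carbon of the sulfonyl aryl ring, para to a large group, the choice of substituent does count in this assay: fluoro brings a 3.9-fold lower number from compound 2 to compound 3 (0.59 log units; beyond the scatter) and a 5.9-fold lower number from compound 1 to compound 3 (0.77 log units; beyond the scatter), whereas methyl in place of hydrogen had stayed within the scatter. The position is therefore not indifferent to what sits on it, and of the three groups seen there, only fluoro sets its compound apart. Nothing measured here bears on the cause.

On these data alone, whether chloro, methoxy or an amine at this carbon would follow fluoro or methyl stays open. So does whether the same change would carry over to a different core.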